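Adding a chloro group to the anilino ring of compound 3

The source may report more compounds than this note shows. Statements on the series, on what has been measured and on what is new or still open speak of the compounds shown alone.

Three compounds have so far been measured in a functional assay on SK-HEP1 cells (Homo sapiens) for cytotoxicity, read by sulforhodamine B assay, with a stated time of 72 h; on this read-out higher numbers stand for weaker inhibition and lower numbers for stronger inhibition:

compound 1, `CCS(=O)(=O)Nc1cc(-c2ccc3ncnc(Nc4ccc(F)cc4F)c3c2)cnc1OC`: 2490 nM
compound 2, `CCS(=O)(=O)Nc1cc(-c2ccc3ncnc(Nc4ccc(OC(F)(F)F)cc4)c3c2)cnc1OC`: 6140 nM
compound 3, `CCS(=O)(=O)Nc1cc(-c2ccc3ncnc(Nc4ccc(OC)cc4)c3c2)cnc1OC`: 1610 nM

Compound 3 gives the lowest of the three numbers, but its separation from compound 1 is small, as a 1.5-fold lower number from compound 1 to compound 3 (0.19 log units; within the scatter) shows, so the two cannot be ranked against each other. Its separation from compound 2 is clearer: a 3.8-fold lower number from compound 2 to compound 3 (0.58 log units; beyond the scatter). Compound 4, `CCS(=O)(=O)Nc1cc(-c2ccc3ncnc(Nc4ccc(OC)c(Cl)c4)c3c2)cnc1OC`, differs from compound 3 in one place: chloro in place of hydrogen on an aromatic carbon. For the measured compounds named here, none of the measured steps adds or removes a chloro group; the steps that exist, a 2.5-fold higher number from compound 1 to compound 2 (0.39 log units; beyond the scatter) and a 3.8-fold lower number from compound 2 to compound 3 (0.58 log units; beyond the scatter), alter the whole aryl group or the group on its oxygen and are themselves modest. Going by the values given here, with no closer precedent, the step from compound 3 to compound 4 is expected to be a 1.1-fold lower number from compound 3 to compound 4 (0.03 log units; within the scatter), that is, not beyond the scatter in either direction. Compound 4 is therefore estimated at 1500 nM in this assay, with a range from 500 nM to 5000 nM.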

Compound 4, half-maximal inhibitory concentration: 2810 nM
Compound 4: the middle estimate sits 1.9-fold (0.27 log units) below what was measured, and the stated range covers the measured number.
By their numbers in this assay, from the lowest: compounds 3, 1 and 4 (each within the scatter of the next); then compound 2.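

For the compounds shown here, this is the first measured step that keeps the methoxy group and adds a chloro group, on the aromatic carbon ortho to it, and in this assay the addition stays within the scatter: a 1.7-fold higher number from compound 3 to compound 4 (0.24 log units; within the scatter). The 3-chloro-4-methoxyphenyl group cannot be told apart from 2,4-difluorophenyl, a 1.1-fold higher number from compound 1 to compound 4 (0.05 log units; within the scatter), but it is separated from 4-(trifluoromethoxy)phenyl, a 2.2-fold lower number from compound 2 to compound 4 (0.34 log units; beyond the scatter), so this position tolerates a chloro group on the present numbers. No evidence is available that would account for these steps.

On these data alone, whether a fluoro, bromo or methyl group at the same position would also stay within the scatter remains open. So does whether a chloro group would read the same on the aryl groups of compound 1 or compound 2.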